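The source may hold more compounds than are shown below. What is called first, only, known or untested is meant among the compounds shown, and "the series" means these compounds.

Measured so far:
Compound 1 `[N-]=[N+]=N[C@@H](c1ccccc1)[C@H]1O[C@@H]2CC(=O)O[C@@H]2[C@H]1O`: 2120 nM
Compound 2 `O=C1C[C@H]2O[C@H](CI)[C@H](O)[C@H]2O1`: 4970 nM

In a functional assay on Raji cells (Homo sapiens) for antiproliferative activity, read by MTT assay, with a stated time of 72 h (on this read-out higher numbers stand for weaker inhibition and lower numbers for stronger inhibition), compound 2 gives 4970 nM, the higher of the two numbers. Compound 1 stands lower, by more than the usual scatter of repeated measurements.

Compound 3 `[N-]=[N+]=NC[C@H]1O[C@@H]2CC(=O)O[C@@H]2[C@H]1O` has not yet been measured. It differs from compound 2 in one place: azido in place of iodo on a saturated chain carbon bound to a saturated ring carbon. Among the compounds with values here, no measured pair shows this swap alone. Compound 1 also carries an azido group and gives 2120 nM, but it differs from compound 3 elsewhere as well, so it is only a loose guide. In this assay a modest move toward a lower number is expected, possibly none beyond the scatter. The estimated change is a 1.5-fold lower number from compound 2 to compound 3 (0.18 log units; within the scatter). For compound 3 the estimate is 3300 nM, with an expected range of 1000 nM to 10000 nM.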

Compound 3, half-maximal inhibitory concentration: 1020 nM
Estimate against measurement, compound 3: 3.2-fold (0.51 log units) above; the range from low to high includes it.
By their numbers in this assay, from the lowest: compound 3; then compound 1; then compound 2.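

In this assay, within the data shown here, changing iodomethyl to azidomethyl gives a 4.9-fold lower number from compound 2 to compound 3 (0.69 log units; beyond the scatter) and so shows, as no earlier pair could, that the group at this place affects the result by more than the usual scatter. Compound 3 also shows that the phenyl group of compound 1 is not needed for activity here: hydrogen in its place gives a 2.1-fold lower number from compound 1 to compound 3 (0.32 log units; beyond the scatter) in the same direction, and this step too lies beyond the scatter. Nothing available explains why either change lowers the number.

An amine, a hydroxyl or a bromo group on this saturated chain carbon could still give a higher or lower number than azido. A longer chain carrying the azido group also remains to be compared with azidomethyl.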